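The compounds below may be only part of what the source reports. "The series", "measured", "known", "first", "only" and "open" are said of these compounds alone.

For the measured compounds named here, in a functional assay on HCT-116 cells (Homo sapiens) for inhibition, with a stated time of 72 h (a higher number here means a weaker inhibitor, a lower number a stronger inhibitor), compound 1 `NC1CCC(Nc2nc(NCc3ccc(-c4ccco4)cc3)c3ncn(C4CCCC4)c3n2)CC1` gives 129 nM and stands lowest of the three numbers measured so far. Compound 2 `NC1CCC(Nc2nc(NCc3ccc(-c4ccsc4)cc3)c3ncn(C4CCCC4)c3n2)CC1` gives 315 nM and compound 3 `CC(C)(O)CNc1nc(NCc2ccc(-c3ccco3)cc2)c2ncn(C3CCCC3)c2n1` gives 16700 nM in the same read-out. Compound 4 `NC1CCC(Nc2nc(NCc3ccc(-c4ccsc4)nc3)c3ncn(C4CCCC4)c3n2)CC1` has not yet been measured. Its change from compound 1 is 6-(thiophen-3-yl)pyridin-3-yl in place of 4-(furan-2-yl)phenyl on a saturated chain carbon bound to a nitrogen on an aromatic ring and leaves the 4-aminocyclohexyl group in place.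

Part of this change has a measured counterpart: thiophen-3-yl in place of furan-2-yl gave a 2.4-fold higher number from compound 1 to compound 2 (0.39 log units; beyond the scatter) as a modest step. Also measured is a 130-fold higher number from compound 1 to compound 3 (2.11 log units; beyond the scatter) as a large step, but that one removes the 4-aminocyclohexyl group, which compound 4 keeps, so it does not bear on this change. Going by the values given here, no measured compound carries a pyridin-3-yl ring, so that part of the change is untested and could move the number either way. A modest step toward a higher number in this assay is therefore expected, resting on compound 2 at 315 nM and with a wide margin. The expected size is a 3.3-fold higher number from compound 1 to compound 4 (0.51 log units; beyond the scatter) as an estimate. For compound 4 the estimated value is 420 nM with an expected range from 130 nM to 1300 nM in this read-out.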

Compound 4, half-maximal inhibitory concentration: 145 nM
Compound 4: middle estimate off by 2.9-fold (0.46 log units), on the high side, and the stated range covers the measured number.
By their numbers in this assay, from the lowest: compounds 1 and 4 (each within the scatter of the next); then compound 2; then compound 3.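

For the compounds shown here, compound 2 and compound 4 both carry thiophen-3-yl, so this pair gives the first reading of the ring change alone at this position, on a saturated chain carbon bound to a nitrogen on an aromatic ring: in this assay, replacing the six-membered aromatic ring of carbon only with a pyridin-3-yl ring gives a 2.2-fold lower number from compound 2 to compound 4 (0.34 log units; beyond the scatter). The full replacement of 4-(furan-2-yl)phenyl by 6-(thiophen-3-yl)pyridin-3-yl gives a 1.1-fold higher number from compound 1 to compound 4 (0.05 log units; within the scatter), so the step seen on going to thiophen-3-yl alone does not persist once the pyridin-3-yl ring is also present, and the position tolerates both changes together with no step beyond the scatter. Nothing measured here explains this shift in the numbers, and no independent data on these groups are available.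

The compounds shown leave open what a 6-(furan-2-yl)pyridin-3-yl group would give, which would show whether the ring step holds with furan-2-yl as it does with thiophen-3-yl. They also leave open how an amine or a carboxylic acid on the pyridin-3-yl ring in place of thiophen-3-yl would read, and whether 2-hydroxy-2-methylpropyl would respond to the ring change as 4-aminocyclohexyl does.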